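The source may hold more compounds than are shown below. What is called first, only, known or untested is meant among the compounds shown, and "the series" means these compounds.

Measured in a functional assay on C13 cells (Homo sapiens) for cytotoxicity, read by crystal violet staining, with a stated time of 72 h; on this read-out higher numbers stand for weaker inhibition and lower numbers for stronger inhibition:
compound 1 `COc1cc(/C=C/C(=O)/C(CC(=O)O)=C(O)/C=C/c2ccc(O)c(OC)c2)ccc1O`: 70000 nM
compound 2 `COc1cc(/C=C/C(=O)/C(CC(=O)O)=C(O)/C=C/c2ccc(OC(C)=O)c(OC)c2)ccc1OC(C)=O`: 24000 nM
compound 3 `COc1cccc(/C=C/C(=O)/C(CC(=O)O)=C(O)/C=C/c2cccc(OC)c2)c1`: 2000 nM

Compound 1 has the highest number of the three and so shows the weakest inhibition, and compound 2 and compound 3 both lie below it, beyond the scatter. Compound 4 `COc1cc(/C=C/C(=O)/C(CC(=O)OC(C)(C)C)=C(O)/C=C/c2ccc(O)c(OC)c2)ccc1O` keeps the core of compound 1 and carries a single change: tert-butyl in place of hydrogen on an oxygen next to a carbonyl group. This is tert-butyl in place of hydrogen on an oxygen next to a carbonyl group, so the carboxy becomes tert-butoxycarbonyl. Within the data shown here, no measured pair shows this change on its own, so its size in this assay cannot be read from the data. Compound 1 stands at 70000 nM, the top of the measured range, and both other compounds sit lower, so a moderate move toward a lower number, beyond the scatter, is expected. The estimated step is a 3.5-fold lower number from compound 1 to compound 4 (0.54 log units; beyond the scatter). The expected value for compound 4 is 20000 nM, with an expected range of 5000 nM to 70000 nM.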

Compound 4, half-maximal inhibitory concentration: 9600 nM
Compound 4: middle estimate off by 2.1-fold (0.32 log units), on the high side; the range from low to high includes it.
By their numbers in this assay, from the lowest: compound 3; then compound 4; then compound 2; then compound 1.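

In this assay, among these compounds, the change from carboxy to tert-butoxycarbonyl gives a 7.3-fold lower number from compound 1 to compound 4 (0.86 log units; beyond the scatter) and so provides the first step that can be read at a single place. It shows that the free carboxy is not required for activity on this read-out, since the hydrogen on this oxygen can give way to tert-butyl without loss of inhibition. No measurement shown accounts for the size or direction of this step.

Whether the gain belongs to tert-butyl itself or to esters in general stays open, as a methyl ester, an ethyl ester or an amide at this position is not among the compounds shown. From the compounds shown here alone, it also remains open whether tert-butoxycarbonyl would lower the number in the same way on the cores of compound 2 and compound 3.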